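Cyclopropyl for tert-Butyl on the Amine Side Chain

The compounds below may be only part of what the source reports. "The series", "measured", "known", "first", "only" and "open" are said of these compounds alone.

Measured in an assay on isolated protein for inhibition of B1 bradykinin receptor (Homo sapiens); a lower number here means a stronger inhibitor, a higher number a weaker inhibitor:
Compound 1, `CC(C)(C)NCc1ccc2c(c1)CCC[C@H]2NC(=O)C[C@@H]1CCCCN1S(=O)(=O)c1ccccc1`: 1700 nM
Compound 2, `CC(C)(C)NCc1ccc2c(c1)CCC[C@H]2NC(=O)C[C@@H]1CCCCN1S(=O)(=O)c1ccc(Cl)cc1`: 560 nM
Compound 3, `CC(C)(C)CNCc1ccc2c(c1)CCC[C@H]2NC(=O)C[C@@H]1CCCCN1S(=O)(=O)c1cccc(C(F)(F)F)c1`: 59 nM

Compound 3 stands at the lowest number of the three. Compound 2 gives 560 nM in this assay, and compound 1 gives 1700 nM, so compound 3 lies well beyond the scatter from both. Among the compounds with values here, the only single-point step measured so far is a 3.0-fold lower number from compound 1 to compound 2 (0.48 log units; beyond the scatter), a change on the aromatic ring of the sulfonyl group; it concerns a position untouched by the change now at hand, so it gives no direct guide.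

Compound 4, `O=C(C[C@@H]1CCCCN1S(=O)(=O)c1cccc(C(F)(F)F)c1)N[C@@H]1CCCc2cc(CNCC3CC3)ccc21`, differs from compound 3 in one place: cyclopropyl in place of tert-butyl on a saturated chain carbon bound to an amine nitrogen, that is, neopentylamino becomes (cyclopropylmethyl)amino. Within the data shown here, no measured pair varies this group, so the expectation rests on the closeness of the two groups in size and character alone, with nothing in the data to argue for a large shift either way. He expects the step of a 1.7-fold higher number from compound 3 to compound 4 (0.23 log units; within the scatter) to stay within or just beyond the scatter, if anything toward a slightly higher number. His estimate for compound 4 in this assay is therefore 100 nM, with a range from 40 nM to 300 nM.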

Compound 4, half-maximal inhibitory concentration: 16 nM
For compound 4 the middle estimate is 6.3-fold (0.80 log units) above the measured one; measured number below the stated range.
By their numbers in this assay, from the lowest: compound 4; then compound 3; then compound 2; then compound 1.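

The change from tert-butyl to cyclopropyl on a saturated chain carbon bound to an amine nitrogen brings a 3.7-fold lower number from compound 3 to compound 4 (0.57 log units; beyond the scatter) in this assay. This is the first single-point step shown at the amine side chain, as the only earlier step concerned the aromatic ring of the sulfonyl group, and it shows that this position responds measurably: exchanging one all-carbon group for another, with no hydrogen-bond donor or acceptor entering or leaving, moves the number beyond the scatter. Nothing given here bears on why the number falls, so the step stands as an observation only.

The compounds shown leave open whether the three-membered ring itself matters or whether other groups on the same carbon, such as isopropyl, cyclobutyl or an unbranched propyl chain, would serve equally well. Within the data shown here, they also leave open whether (cyclopropylmethyl)amino would give a step of similar size when paired with the sulfonyl groups of compound 1 and compound 2, since the change has been seen only with the trifluoromethyl-bearing sulfonyl group of compound 3.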